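The compounds below may be only part of what the source reports. "The series", "measured", "known", "first", "only" and "open" are said of these compounds alone.

Measured in an ADME assay on the whole organism (plasma) for pharmacokinetics, with Rattus norvegicus as the target, with a stated time of 6 h, at a dose of 10 mg/kg by the oral route; on this read-out higher numbers stand for higher exposure at the dose given and lower numbers for lower exposure:
- compound 1 `CC1(COc2c(N3CCN(S(=O)(=O)Cc4ccc(N)cc4)CC3)cnn(-c3cccc(Cl)c3)c2=O)CC1`: 8100 ng.h/mL
- compound 2 `CCc1cc(CS(=O)(=O)N2CCN(c3cnn(-c4cccc(Cl)c4)c(=O)c3OCC3(C)CC3)CC2)ccc1N`: 9400 ng.h/mL

Within the data shown here, compound 2 stands level with the only other measured compound, within the scatter. Among the measured compounds shown here, the single measured step is a 1.2-fold higher number from compound 1 to compound 2 (0.06 log units; within the scatter), with ethyl in place of hydrogen on an aromatic carbon.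

The next compound is compound 3 `CC(C)c1cc(CS(=O)(=O)N2CCN(c3cnn(-c4cccc(Cl)c4)c(=O)c3OCC3(C)CC3)CC2)ccc1N`, with the change (methyl in place of hydrogen on a saturated chain carbon bound to an aromatic carbon and a saturated chain carbon). This is methyl in place of hydrogen on a saturated chain carbon bound to an aromatic carbon and a saturated chain carbon, so 4-amino-3-ethylbenzyl becomes 4-amino-3-isopropylbenzyl.

For the measured compounds named here, only that one measured step bears on this change, and it is a different change on the same group. One step is thin evidence, but no shift beyond the scatter is expected, in either direction, because a 1.2-fold higher number from compound 1 to compound 2 (0.06 log units; within the scatter) stayed within it. The expected step is a 1.1-fold lower number from compound 2 to compound 3 (0.04 log units; within the scatter). Compound 3 is estimated at 8500 ng.h/mL, with an expected range of 4000 ng.h/mL to 17000 ng.h/mL.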

Compound 3, area under the concentration-time curve: 2100 ng.h/mL
Compound 3: middle estimate off by 4.0-fold (0.61 log units), on the high side; the whole stated range lies above it.
By their numbers in this assay, from the lowest: compound 3; then compounds 1 and 2 (each within the scatter of the next).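

In this assay, going from ethyl to isopropyl on the 4-amino-3-ethylbenzyl group gives a 4.5-fold lower number from compound 2 to compound 3 (0.65 log units; beyond the scatter), whereas hydrogen to ethyl on the same aromatic carbon stayed within the scatter, with a 1.2-fold higher number from compound 1 to compound 2 (0.06 log units; within the scatter). Isopropyl in place of hydrogen gives a 3.9-fold lower number from compound 1 to compound 3 (0.59 log units; beyond the scatter), so along hydrogen, ethyl and isopropyl the number does not fall evenly: the drop appears only with the last methyl. Nothing measured on these compounds accounts for the drop.

Still open, going by these compounds, is whether the drop goes with branching at the chain carbon or with the added carbon alone, which a straight propyl chain on the same aromatic carbon would help separate. Also open, on these data alone, is whether a cyclopropyl ring there would stay level with compound 2 or fall with compound 3.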